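Furan-2-yl in place of (pyridin-3-yl)methyl: an inactive pair

The source may report more compounds than this note shows. Statements on the series, on what has been measured and on what is new or still open speak of the compounds shown alone.

Compound 1 `CCOC(=O)c1ccc(-c2nn(Cc3cccc(Cl)c3)c3ccccc23)cc1` in a functional assay on cells (Platelet, Homo sapiens) for inhibition (a lower number here means a stronger inhibitor, a higher number a weaker inhibitor), gives > 10000 nM, which is a limit of the assay.
Compound 2 `CCOC(=O)c1ccc(-c2nn(Cc3cccnc3)c3ccccc23)cc1` in this assay gives > 10000 nM, likewise a limit.

Going by the values given here, compound 2 therefore stands at the measuring limit, shared with the one other compound measured: the limit of > 10000 nM in this assay, at which 2 of the 2 values shown sit. Among the compounds with values here, the only measured step, a step that the two limits leave unreadable from compound 1 to compound 2, runs between two limits, so its size cannot be read.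

Compound 3 `CCOC(=O)c1ccc(-c2nn(-c3ccco3)c3ccccc23)cc1` differs from compound 2 by furan-2-yl in place of (pyridin-3-yl)methyl on an aromatic nitrogen. Within the data shown here, no measured step bears on this change with a readable size, so nothing in the numbers points to a gain or a loss in this assay beyond the scatter. With both measured compounds sitting at the limit, the plain expectation is that compound 3 stays there too, and any real difference would be hidden by that limit.

Compound 3 is estimated at 20000 nM in this assay, with a range from 5000 nM to 100000 nM. The step this estimate means, a step that the limit leaves unreadable from compound 2 to compound 3, is expected to lie within the scatter.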

Compound 3, half-maximal inhibitory concentration: > 10000 nM
Compound 3 gave a limit, no number (the forecaster's own chance of this, stated with the estimate: 85%); the middle value lies beyond the limit too.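

Compound 3 also gives a limit of the assay rather than a number, so none of the steps linking compound 1, compound 2 and compound 3 can be read, and all three compounds share one limit: the limit of > 10000 nM in this assay, at which 3 of the 3 values shown sit.

The compounds shown leave open whether any group on the aromatic nitrogen could bring a readable value in this assay.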